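A few compounds are considered here, and "the series" means these few. Any claim that something is new, unique, unknown or untested is made for them only; others in the source may bear on it.

Measured so far:
compound 1 `COc1cccc(Oc2c(NS(=O)(=O)c3ccc(C(C)(C)C)cc3)ncnc2OCCO)c1`, 160 nM
compound 2 `COc1cccc(Oc2c(NS(=O)(=O)c3ccc(C(C)(C)C)cc3)ncnc2OCCOc2ncccn2)c1`, 1.9 nM
compound 3 `COc1cccc(Oc2c(NS(=O)(=O)c3ccc(C(C)(C)C)cc3)ncnc2OCCOc2ccncn2)c1`, 1.2 nM

All three share one core and were tested in an assay on cells (Endothelial cell) for binding affinity to Endothelin-1 receptor (Sus scrofa); a lower number here means a stronger inhibitor, a higher number a weaker inhibitor. Compound 1 stands at the highest number of the three, which makes it the weakest inhibitor of the set. The step of an 84-fold lower number from compound 1 to compound 2 (1.93 log units; beyond the scatter) and the step of a 130-fold lower number from compound 1 to compound 3 (2.12 log units; beyond the scatter) are both large, while the two ring-bearing compounds sit within the scatter of each other: a 1.6-fold lower number from compound 2 to compound 3 (0.20 log units; within the scatter).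

Compound 4 `COc1cccc(Oc2c(NS(=O)(=O)c3ccc(C(C)(C)C)cc3)ncnc2OCCOc2ncc(C)cn2)c1` carries the change (5-methylpyrimidin-2-yl in place of hydrogen on an oxygen on a saturated carbon). Within the data shown here, the entering group closely resembles the one present in compound 2, so the steps from compound 1 to compounds 2 and 3 are the ones that bear on it, and both were large and in the same direction. A comparably large drop in this assay is therefore expected, giving the estimated step of a 64-fold lower number from compound 1 to compound 4 (1.81 log units; beyond the scatter). For compound 4 the value is estimated at 2.5 nM, with a likely range from 0.8 nM to 8 nM.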

Compound 4, half-maximal inhibitory concentration: 0.86 nM
The estimate for compound 4 lay 2.9-fold (0.46 log units) above the measured number; the measured number falls inside the stated range.
By their numbers in this assay, from the lowest: compounds 4, 3 and 2 (each within the scatter of the next, the first and the last beyond it); then compound 1.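

In this assay, the oxygen of the 2-hydroxyethyl chain also accepts a ring that carries a substituent: 5-methylpyrimidin-2-yl in place of hydrogen gives a large step (a 190-fold lower number from compound 1 to compound 4 (2.27 log units; beyond the scatter)), the largest of the three from compound 1 in size. Among these compounds, the methyl on an aromatic carbon is the only difference in one pair (a 2.2-fold lower number from compound 2 to compound 4 (0.34 log units; beyond the scatter)), a modest step that lies just beyond the scatter, while a different comparison (a 1.4-fold lower number from compound 3 to compound 4 (0.14 log units; within the scatter)) stays within the scatter, so those two compounds cannot be ranked. Nothing measured here explains what the ring or the methyl does to the binding.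

On these data alone, whether a methoxy group or a chlorine in place of that methyl would do the same remains open. So does whether a ring is needed at all, since a plain methyl or an amine-bearing chain on the same oxygen could show.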